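Swapping Chloro for Bromo: Expectation for Compound 4

A few compounds are considered here, and "the series" means these few. Any claim that something is new, unique, unknown or untested is made for them only; others in the source may bear on it.

Of the compounds shown here, three have been tested in a functional assay on L1210 cells (Mus musculus) for cytotoxicity, with a stated time of 48 h (a lower number here means a stronger inhibitor, a higher number a weaker inhibitor), and a fourth waits to be measured. Compound 1 `Clc1ccc(Cc2nn3c(Br)c(-c4ccc(Cl)cc4)nc3s2)cc1` did not give a number in this assay: its value > 250000 nM is a limit of the assay. Compound 2 `Clc1ccc(Cc2nn3c(Br)c(-c4ccc(Br)cc4)nc3s2)cc1` likewise returned only a limit, > 250000 nM. Within the data shown here, compound 3 `N#CSc1c(-c2ccc(Cl)cc2)nc2sc(Cc3ccc(Cl)cc3)nn12` is the one compound with a real number, giving 49000 nM in this assay.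

Compound 1 and compound 2 differ only by bromo in place of chloro on an aromatic carbon. Their step, a step that the two limits leave unreadable from compound 1 to compound 2, cannot be read, because both values sit at the limit of > 250000 nM in this assay, at which 2 of the 3 values shown sit. Compound 1 and compound 3 differ in their cores by cyanosulfanyl in place of bromo on an aromatic carbon, and this change gives an at least 5.1-fold lower number from compound 1 to compound 3 (0.70 log units; beyond the scatter).

Compound 4 `N#CSc1c(-c2ccc(Br)cc2)nc2sc(Cc3ccc(Cl)cc3)nn12` has not yet been measured. It differs from compound 3 by bromo in place of chloro on an aromatic carbon, the same change that separates compound 1 from compound 2. Among the measured compounds shown here, that earlier step is unreadable, so the only guide is that a single halogen exchange of this kind is a small structural change. Compound 4 is therefore expected to land close to compound 3, with an estimated step of a 1.1-fold lower number from compound 3 to compound 4 (0.04 log units; within the scatter). In this assay compound 4 is estimated to give 45000 nM, most likely between 18000 nM and 120000 nM.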

Compound 4, half-maximal inhibitory concentration: 81000 nM
Beside the measured number, compound 4's estimate is 1.8-fold (0.26 log units) below it; measured number inside the range.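

In this assay, exchanging 4-chlorophenyl for 4-bromophenyl gives a 1.7-fold higher number from compound 3 to compound 4 (0.22 log units; within the scatter), so on the cores that carry cyanosulfanyl this halogen exchange makes no difference that can be told from ordinary assay scatter. The other change in the series, cyanosulfanyl in place of bromo, now appears on a second core, where it gives an at least 3.0-fold lower number from compound 2 to compound 4 (0.48 log units; beyond the scatter), and the two cases can be set side by side: the same change on two cores in this assay, an at least 5.1-fold lower number (0.70 log units; beyond the scatter) from compound 1 to compound 3 and an at least 3.0-fold lower number (0.48 log units; beyond the scatter) from compound 2 to compound 4; the limit leaves it open whether they differ. From the compounds shown here alone, the change therefore moves the number in the same direction on both cores, but its true size on either core remains unknown and the step from compound 1 to compound 2 cannot be read, as the two bromo compounds give no actual number: the limit of > 250000 nM in this assay, at which 2 of the 4 values shown sit.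

The compounds shown leave open whether other groups at the place held by cyanosulfanyl, such as an amine, a methylthio group or a plain nitrile, would also give a readable number. They also leave open how the 4-chlorophenyl and 4-bromophenyl positions would respond to a different substituent, such as methoxy or a carboxylic acid, and whether the small difference seen with these two halogens would hold there.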